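The compounds below may be only part of what the source reports. "The series", "measured", "known", "first", "only" and "open" are said of these compounds alone.

Compound 1, with the structure `COc1ccc(S(=O)(=O)c2cnc3ccc(C)cc3c2N2CCC(C)CC2)cc1Cl`, is the starting point of this small set. In an assay on isolated protein for displacement of a labelled ligand from metabotropic glutamate receptor 5 (Homo sapiens), with a stated time of 60 min, tested at 1 uM (on this read-out lower numbers stand for less inhibition and higher numbers for more inhibition at the one concentration tested (going by the name of the read-out)), compound 1 gives 93%. Compound 2, with the structure `Cc1ccc(S(=O)(=O)c2cnc3ccc(C)cc3c2N2CCC(C)CC2)cc1`, differs from compound 1 in one place only: 4-methylphenyl in place of 3-chloro-4-methoxyphenyl on a sulfonyl sulfur. In this assay compound 2 gives 82%, so the change a number 11 percentage points lower from compound 1 to compound 2 (beyond the scatter).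

Compound 3, with the structure `COc1ccc(S(=O)(=O)c2cnc3ccc(F)cc3c2N2CCC(C)CC2)cc1Cl`, keeps the group on the sulfonyl sulfur of compound 1 but carries a different core; the two cores differ in one counted place: fluoro in place of methyl on an aromatic carbon. In this assay compound 3 gives 82%, so the change a number 11 percentage points lower from compound 1 to compound 3 (beyond the scatter). Compound 3 and compound 2 therefore stand level at the digits reported.

Compound 4, with the structure `Cc1ccc(S(=O)(=O)c2cnc3ccc(F)cc3c2N2CCC(C)CC2)cc1`, has not yet been measured. It differs from compound 3 in one place: 4-methylphenyl in place of 3-chloro-4-methoxyphenyl on a sulfonyl sulfur. This is the same change that was made from compound 1 to compound 2, and it sits on the same kind of place in both pairs. Since that change gave a number 11 percentage points lower from compound 1 to compound 2 (beyond the scatter), a step of similar size is expected from compound 3 to compound 4, namely a number 10 percentage points lower from compound 3 to compound 4 (within the scatter), with some allowance for the reading of compound 3 already being lower than that of compound 1. For compound 4 the estimated value in this assay is therefore 72%, expected to lie between 58% and 84%.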

Compound 4, a percentage reported as inhibition, at one concentration (the size of the read-out at that concentration, not a potency): 91%
Compound 4: the middle estimate sits 19 percentage points below what was measured; measured number above the stated range.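

Replacing 3-chloro-4-methoxyphenyl with 4-methylphenyl on the sulfonyl sulfur does not carry over cleanly from the core of compound 1 to the core of compound 3 in this assay: on the second core the step is a number 9 percentage points higher from compound 3 to compound 4 (within the scatter), and the comparison with the first core reads: the same change on two cores in this assay, a number 11 percentage points lower (beyond the scatter) from compound 1 to compound 2 and a number 9 percentage points higher (within the scatter) from compound 3 to compound 4, 20 percentage points apart, beyond the scatter of two such steps

The same holds for fluoro in place of methyl on an aromatic carbon, where the step with the 4-methylphenyl group is a number 9 percentage points higher from compound 2 to compound 4 (within the scatter), so the effect of each change here depends on the other part of the molecule: the same change on two cores in this assay, a number 11 percentage points lower (beyond the scatter) from compound 1 to compound 3 and a number 9 percentage points higher (within the scatter) from compound 2 to compound 4, 20 percentage points apart, beyond the scatter of two such steps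

This does not show why the two changes fail to add up, nor that the number of compound 4 truly differs from that of compound 3 or compound 2, since each new step on its own lies within the scatter, and four compounds read at one concentration cannot establish a rule for the wider series.

The compounds shown leave open whether this dependence would persist with a plain phenyl, or with a phenyl carrying only the chloro or only the methoxy group, on the sulfonyl sulfur. They also leave open what happens with a chloro or nitrile group in place of the fluoro or methyl on the core, and how the compounds would rank by potency rather than by a reading at one concentration.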